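A few compounds are considered here, and "the series" means these few. Any claim that something is new, unique, unknown or untested is made for them only; others in the source may bear on it.

Working notes on the series, an ADME assay on HEK-293T cells (Homo sapiens) for cytotoxicity, read by MTT assay, with a stated time of 24 h; on this read-out lower numbers stand for higher toxicity in this test and higher numbers for lower toxicity in this test:

- compound 1, `Cc1ccccc1C(=O)n1c(-c2cn(-c3ccccc3)nc2-c2ccc(F)cc2)nc2ccccc21`, gives 189000 nM
- compound 2, `Cc1ccc(C(=O)n2c(-c3cn(-c4ccccc4)nc3-c3ccc(C(F)(F)F)cc3)nc3ccccc32)cc1`, gives 169000 nM
- compound 3, `Cc1ccc(C(=O)n2c(-c3cn(-c4ccccc4)nc3-c3ccc(F)cc3)nc3ccccc32)cc1`, gives 178000 nM

All three numbers in this assay sit close together. Compound 3 stands with the other two within the scatter on either side: a 1.1-fold lower number from compound 1 to compound 3 (0.03 log units; within the scatter) and a 1.1-fold higher number from compound 2 to compound 3 (0.02 log units; within the scatter) are both small steps, and neither reaches beyond the usual scatter of repeats. The three compounds share a core and differ only in the aryl group on the carbonyl carbon or in the substituent on the aromatic carbon of the fluorophenyl or trifluoromethylphenyl ring; none of these exchanges has moved the read-out.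

Compound 4, `Cc1cncc(C(=O)n2c(-c3cn(-c4ccccc4)nc3-c3ccc(F)cc3)nc3ccccc32)c1`, is not yet measured. Relative to compound 3 the change is 5-methylpyridin-3-yl in place of 4-methylphenyl on a carbonyl carbon. Among the compounds with values here, the only measured step at this place is a 1.1-fold lower number from compound 1 to compound 3 (0.03 log units; within the scatter), an exchange of one methylphenyl isomer for another on the carbonyl carbon, and it stayed within the scatter. Within the data shown here, no measured step exchanges a carbon ring for a ring holding a nitrogen, so there is no direct precedent for this change. On the pattern seen in compound 1, compound 2 and compound 3, the expectation for this assay is no step beyond the scatter, a 1.0-fold lower number from compound 3 to compound 4 (0.01 log units; within the scatter). Compound 4 is therefore estimated at 175000 nM, with a range from 85000 nM to 360000 nM.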

Compound 4, half-maximal cytotoxic concentration: 119000 nM
Estimate against measurement, compound 4: 1.5-fold (0.17 log units) above; the range from low to high includes it.
By their numbers in this assay, from the lowest: compounds 4, 2, 3 and 1 (each within the scatter of the next).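

In this assay, the exchange of a carbon ring for a ring holding a nitrogen on the carbonyl carbon now has a measured precedent, a 1.5-fold lower number from compound 3 to compound 4 (0.17 log units; within the scatter), and the same group set against the other methylphenyl isomer gives a 1.6-fold lower number from compound 1 to compound 4 (0.20 log units; within the scatter), so neither exchange reaches beyond the scatter at this position. The entering 5-methylpyridin-3-yl keeps the heavy-atom count of the groups it replaces and adds a hydrogen-bond acceptor, and this addition comes without a step beyond the scatter in this read-out. Nothing available bears on why the values fall where they do.

As far as these compounds go, with the four compounds each within the scatter of the next, it stays open whether any group on the carbonyl carbon can move this read-out beyond the scatter; an amine, a carboxylic acid or a longer alkyl chain in place of the methyl on that ring would address this. Also open, from the compounds shown here alone, is whether a ring with more than one nitrogen, or a pyridine ring without the methyl, would stay within the scatter as 5-methylpyridin-3-yl does.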